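Methoxy for methyl in two quinazolinone acetamide series

The source may report more compounds than this note shows. Statements on the series, on what has been measured and on what is new or still open speak of the compounds shown alone.

Compound 1 `Cc1ccc([C@H](C)NC(=O)Cn2nnc3ccccc3c2=O)c(C)c1` and compound 2 `COc1cc(C)ccc1[C@H](C)NC(=O)Cn1nnc2ccccc2c1=O` share one core, and compound 3 `Cc1ccc([C@H](C)NC(=O)C(C)n2nnc3ccccc3c2=O)cc1` carries a second core built from the same atoms joined differently; how the two cores differ is not broken down here. In an ADME assay on microsomes from liver (Homo sapiens) for metabolic stability (on this read-out higher numbers stand for fast clearance and lower numbers for slow clearance), compound 1 gives 33 mL/min/kg and compound 2 gives 30 mL/min/kg. The change between them, (methoxy in place of methyl on an aromatic carbon), made a 1.1-fold lower number from compound 1 to compound 2 (0.04 log units; within the scatter). Compound 3 gives 13 mL/min/kg in this assay, the lowest of the three numbers; its gap to compound 2 and to compound 1 lies beyond the scatter in both cases.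

Compound 4 `COc1ccc([C@H](C)NC(=O)C(C)n2nnc3ccccc3c2=O)cc1` is not yet measured. It stands to compound 3 as compound 2 stands to compound 1: methoxy in place of methyl on an aromatic carbon. The surroundings of the place differ, however. In compound 1 the exchanged group sits ortho to a large group and meta to a methyl group (1 heavy atom); in compound 3 it sits para to a large group. The change is therefore of the same kind, not the same.

Among the measured compounds shown here, only one measured instance of this change exists, and it stayed within the scatter. On that basis the step from compound 3 to compound 4 in this assay is expected to be small as well, near no change at the digits printed from compound 3 to compound 4 (within the scatter), resting on compound 1 to compound 2 giving a 1.1-fold lower number from compound 1 to compound 2 (0.04 log units; within the scatter). Compound 4 is thus estimated at 13 mL/min/kg in this assay, with a range from 7 mL/min/kg to 25 mL/min/kg.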

Compound 4, clearance: < 9.9 mL/min/kg
Compound 4: a limit, no number; the forecaster's own chance of this, stated with the estimate: 5%; middle value at least 1.3-fold (0.11 log units) from the limit.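

In this assay compound 4 gives < 9.9 mL/min/kg, which is a limit of the assay and not a number. Methoxy in place of methyl on an aromatic carbon, here 4-methylphenyl to 4-methoxyphenyl, gives an at least 1.3-fold lower number from compound 3 to compound 4 (0.11 log units; that floor lies within the scatter), so only a floor on the size of the step is known, and that floor does not establish a step beyond the scatter. The notes therefore show that the change can be carried to the second core without a rise in the clearance number, but they do not show that it has the same size on both cores, and with only two instances, in different surroundings, no transfer rule follows: the same change on two cores in this assay, a 1.1-fold lower number (0.04 log units; within the scatter) from compound 1 to compound 2 and an at least 1.3-fold lower number (0.11 log units; that floor lies within the scatter) from compound 3 to compound 4; the limit leaves it open whether they differ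

The compounds shown hold only methyl and methoxy at this place, so it remains open how an ethoxy group, an amine or a carboxylic acid para to a large group would read on either core in this assay. Also open is how far compound 4 lies under its limit, which leaves little room for reading further changes from that compound: the limit of < 9.9 mL/min/kg in this assay, at which 1 of the 4 values shown sits.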